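Ortho methoxy on the aryl of the pyrazoline thiourea series

The source may hold more compounds than are shown below. What is called first, only, known or untested is meant among the compounds shown, and "the series" means these compounds.

Compound 2 `Cc1ccc(C2=NN(C(=S)Nc3ccccc3)C(c3ccc4c(c3)OCCO4)C2)cc1` reaches only a limit in a functional assay on HCT-116 cells (Homo sapiens) for antiproliferative activity, read by MTT assay, with a stated time of 48 h (a lower number here means a stronger inhibitor of growth, a higher number a weaker inhibitor of growth), giving > 200000 nM. The step to compound 4 `COc1ccccc1C1=NN(C(=S)Nc2ccccc2)C(c2ccc3c(c2)OCCO3)C1` is 2-methoxyphenyl in place of 4-methylphenyl on a carbon with a double bond to nitrogen. Among the compounds with values here, two measured steps bear on it: from compound 1 `S=C(Nc1ccccc1)N1N=C(c2ccccc2)CC1c1ccc2c(c1)OCCO2`, which gives 57600 nM in this assay, to compound 2 the number rose by an at least 3.4-fold higher number from compound 1 to compound 2 (0.54 log units; beyond the scatter), and to compound 3 `S=C(Nc1ccccc1)N1N=C(c2ccccc2Br)CC1c1ccc2c(c1)OCCO2`, which gives 195000 nM, by a 3.4-fold higher number from compound 1 to compound 3 (0.53 log units; beyond the scatter). Between compound 2 and compound 3 the difference was an at least 1.0-fold lower number from compound 2 to compound 3 (0.01 log units; that floor lies within the scatter). Substituents at either position on that ring thus left the number near the limit of this assay (the limit of > 200000 nM in this assay, at which 1 of the 3 values shown sits). No step beyond the scatter is expected for compound 4, that is an at least 1.1-fold lower number from compound 2 to compound 4 (0.04 log units; that floor lies within the scatter). Compound 4 is estimated at 180000 nM, in the range 60000 nM to 400000 nM.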

Compound 4, concentration for 50% growth inhibition: > 200000 nM
Compound 4 was reported as a limit (the forecaster's own chance of this, stated with the estimate: 50%); middle value at least 1.1-fold (0.04 log units) from the limit.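

Compound 4 gives only a limit in this assay, so the hydrogen-bond acceptor that enters with 2-methoxyphenyl brings no readable gain in growth inhibition. Methoxy in place of hydrogen gives an at least 3.4-fold higher number from compound 1 to compound 4 (0.54 log units; beyond the scatter), while methoxy in place of bromo gives an at least 1.0-fold higher number from compound 3 to compound 4 (0.01 log units; that floor lies within the scatter). The step from 4-methylphenyl cannot be read, since both ends are limits, and the series now crowds the top of the range: the limit of > 200000 nM in this assay, at which 2 of the 4 values shown sit.

Still open, as far as these compounds go, is whether any substituent on this ring improves on the plain phenyl of compound 1, at 57600 nM. An amine or a carboxylic acid there would test this.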